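The compounds below may be only part of what the source reports. "The series", "measured", "known", "first", "only" and "open" are said of these compounds alone.

Compound 1 `CCCSc1nc(N)nc2c1ncn2/C=C1/CC1(CO)CO` and compound 2 `CCCNc1nc(N)nc2c1ncn2/C=C1/CC1(CO)CO` share one core and differ only in the group on one aromatic carbon. In an ADME assay on BCBL1 cells (Homo sapiens) for cytotoxicity, with a stated time of 7 days (a higher number here means that more compound is tolerated, a lower number that less compound is tolerated), compound 1 gives only a limit of the assay, > 20000 nM. In this assay compound 2 likewise gives only a limit, > 20000 nM. The step that the two limits leave unreadable from compound 1 to compound 2 therefore cannot be read, since both values sit at the limit of > 20000 nM in this assay, at which 2 of the 2 values shown sit. Compound 3 `CCCCSc1nc(N)nc2c1ncn2/C=C1/CC1(CO)CO` carries butylsulfanyl in place of propylamino on an aromatic carbon. Going by the values given here, no measured step speaks to this change, and compound 2 stands only at the limit in this assay. Compound 3 is expected to give 30000 nM, within 15000 nM to 80000 nM. The step that the limit leaves unreadable from compound 2 to compound 3 is expected to stay within the scatter.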

Compound 3, half-maximal cytotoxic concentration: > 20000 nM
Compound 3 ended at the assay's limit; the forecaster's own chance of this, stated with the estimate: 80%; the middle value does not contradict the limit.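

Going by these compounds alone, no step among compound 1, compound 2 and compound 3 can be read, because all three values are limits of the assay: the limit of > 20000 nM in this assay, at which 3 of the 3 values shown sit. Going by these compounds, the concentration at which any of them becomes cytotoxic in this assay stays open.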